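Inverting the amide linkage on the five-membered ring

This account rests on a few compounds, and the source may have more. Where it says the series, first, only, none or still open, it means among the compounds named here.

Compound 3 `Cc1cc(C(=O)NN2CCOCC2)nn1Cc1cc(Cl)ccc1OCC(C)C` gives 251 nM in an assay on CHO-K1 cells for displacement of a labelled ligand from prostaglandin E2 receptor EP1 subtype (Homo sapiens) (on this read-out lower numbers stand for stronger inhibition and higher numbers for weaker inhibition), the highest of the three numbers shown but within the scatter of both others: compound 2 `Cc1cc(C(=O)NN2CCCCC2)nn1Cc1cc(Cl)ccc1OCC(C)C` gives 200 nM and compound 1 `Cc1cc(C(N)=O)nn1Cc1cc(Cl)ccc1OCC(C)C` gives 126 nM, with a 2.0-fold higher number from compound 1 to compound 3 (0.30 log units; within the scatter), a 1.3-fold higher number from compound 2 to compound 3 (0.10 log units; within the scatter) and a 1.6-fold higher number from compound 1 to compound 2 (0.20 log units; within the scatter). Compound 4 `Cc1cc(NC(=O)C2CCCCC2)nn1Cc1cc(Cl)ccc1OCC(C)C` differs from compound 3 by (cyclohexylcarbonyl)amino in place of (morpholin-4-yl)carbamoyl on an aromatic carbon. Within the data shown here, no measured step touches this inversion of the linkage; all three only vary the group on the amide-type nitrogen, and each stayed within the scatter, so no direction is indicated and the uncertainty is wide. A step of a 1.0-fold lower number from compound 3 to compound 4 (0.00 log units; within the scatter) is expected, that is, none beyond the scatter. Compound 4 is estimated at 250 nM, between 60 nM and 1000 nM.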

Compound 4, half-maximal inhibitory concentration: 31.6 nM
The estimate for compound 4 lay 7.9-fold (0.90 log units) above the measured number, and the stated range ends above it.
By their numbers in this assay, from the lowest: compound 4; then compounds 1, 2 and 3 (each within the scatter of the next).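

In this assay, the three groups on the amide-type nitrogen gave no step beyond the scatter, whereas (cyclohexylcarbonyl)amino on this aromatic carbon gives a modest step beyond it against each carbamoyl compound (a 7.9-fold lower number from compound 3 to compound 4 (0.90 log units; beyond the scatter); a 6.3-fold lower number from compound 2 to compound 4 (0.80 log units; beyond the scatter); a 4.0-fold lower number from compound 1 to compound 4 (0.60 log units; beyond the scatter)). So this position responds to a change in the group it carries, although each step alters the linkage and the attached group together. No supporting measurement accounts for the lower number.

On these data alone, how much belongs to the inverted linkage and how much to the cyclohexyl ring stays open. A morpholine ring or a phenyl ring on the inverted amide would help separate the two.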